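This account rests on a few compounds, and the source may have more. Where it says the series, first, only, none or still open, it means among the compounds named here.

In a functional assay on SK-MEL-2 cells (Homo sapiens) for cytotoxicity, read by sulforhodamine B assay, with a stated time of 48 h (on this read-out higher numbers stand for weaker inhibition of growth and lower numbers for stronger inhibition of growth), compound 1 `ClCc1cccc(Cn2cnc3ncnc(Cl)c32)c1` gives 5750 nM, and compound 2 `ClCc1ccccc1Cn1cnc2ncnc(Cl)c21`, built from the same atoms joined differently, gives 4160 nM; the difference between the two cores is not broken down here. Compound 3 `ClCc1cccc(Cn2cnc3nc(Cl)nc(Cl)c32)c1` gives 1770 nM, and the step of a 3.2-fold lower number from compound 1 to compound 3 (0.51 log units; beyond the scatter) followed from chloro in place of hydrogen on an aromatic carbon. Compound 4 `ClCc1ccccc1Cn1cnc2nc(Cl)nc(Cl)c21` has not yet been measured in this assay. It differs from compound 2 by chloro in place of hydrogen on an aromatic carbon, the same change, at a place described in the same words. The expectation for compound 4 rests on compound 1 and compound 3 alone, whose step a 3.2-fold lower number from compound 1 to compound 3 (0.51 log units; beyond the scatter) lay beyond the scatter. A step of similar size is expected here, a 2.6-fold lower number from compound 2 to compound 4 (0.41 log units; beyond the scatter). Compound 4 is therefore estimated at 1600 nM, with a likely range from 800 nM to 3500 nM.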

Compound 4, concentration for 50% growth inhibition: 2750 nM
Compound 4: middle estimate off by 1.7-fold (0.24 log units), on the low side; low and high end bracket the measured number.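

On the core of compound 2, chloro in place of hydrogen on an aromatic carbon gives a 1.5-fold lower number from compound 2 to compound 4 (0.18 log units; within the scatter) in this assay. Set beside the step on the core of compound 1, the two steps cannot be told apart: the same change on two cores in this assay, a 3.2-fold lower number (0.51 log units; beyond the scatter) from compound 1 to compound 3 and a 1.5-fold lower number (0.18 log units; within the scatter) from compound 2 to compound 4, 2.1-fold (0.33 log units) apart, within the scatter of two such steps. The two pairs are thus compatible with the change carrying over between these cores, but they do not show that it does, as the step on the core of compound 2 is not itself distinguishable from scatter.

The compounds shown leave open how an amine or a methoxy group on the same aromatic carbon, between two ring nitrogen atoms, would compare with chloro. They also leave open whether the change would behave alike on any third core.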